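Swapping Cyclohexyl for Isobutyl in a Sulfonamide Series

The compounds below may be only part of what the source reports. "The series", "measured", "known", "first", "only" and "open" are said of these compounds alone.

Compound 1 `O=C1NCCN1c1ccc(S(=O)(=O)Nc2ccc(C3CCCCC3)cc2)cc1` carries a cyclohexyl group on an aromatic carbon. In a functional assay on MCF7 cells (Homo sapiens) for antiproliferative activity, read by sulforhodamine B assay, with a stated time of 48 h (on this read-out higher numbers stand for weaker inhibition and lower numbers for stronger inhibition), compound 1 gives > 1000 nM, which is a limit of the assay rather than a number, so compound 1 stands only at the limit of > 1000 nM in this assay, at which 1 of the 2 values shown sits. Compound 2 `Cc1cc(C)cc(NS(=O)(=O)c2ccc(N3CCNC3=O)cc2)c1`, with two methyl groups in place of that ring, gives 100 nM in this assay. Compound 3 `CC(C)Cc1ccc(NS(=O)(=O)c2ccc(N3CCNC3=O)cc2)cc1` makes one change: isobutyl in place of cyclohexyl on an aromatic carbon. In this assay the step from compound 1 to compound 3 is expected to be an at least 1.4-fold lower number from compound 1 to compound 3 (0.15 log units; that floor lies within the scatter), a modest gain, because compound 1 sits at the limit of > 1000 nM in this assay, at which 1 of the 2 values shown sits, while compound 2 gives 100 nM. Compound 3 is therefore estimated at 700 nM, within 150 nM to 3000 nM.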

Compound 3, half-maximal inhibitory concentration: > 1000 nM
Compound 3 was reported as a limit; the forecaster's own chance of this, stated with the estimate: 40%; middle value at least 1.4-fold (0.15 log units) away from the limit.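

Compound 1 and compound 3 both stop at a limit in this assay rather than at a number, so no step between them can be read: the limit of > 1000 nM in this assay, at which 2 of the 3 values shown sit.

The compounds shown leave open whether isobutyl or cyclohexyl gives stronger inhibition.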